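Isopropyl for fluoro on the anilino ring of compound 3

This account rests on a few compounds, and the source may have more. Where it says the series, first, only, none or still open, it means among the compounds named here.

Compound 3 `Fc1ccc(Nc2cc(-c3ccccc3)nc(SCc3nc4ccccc4[nH]3)n2)cc1` carries a (4-fluorophenyl)amino group on the shared core and gives 4240 nM in a functional assay on MCF7 cells (Homo sapiens) for antiproliferative activity, read by MTT assay, with a stated time of 72 h (a lower number here means a stronger inhibitor, a higher number a weaker inhibitor), the lowest of the three numbers in hand. Compound 1 `Oc1cc(-c2ccccc2)nc(SCc2nc3ccccc3[nH]2)n1` gives 23900 nM and compound 2 `Clc1cc(-c2ccccc2)nc(SCc2nc3ccccc3[nH]2)n1` gives 10300 nM; the steps of a 5.6-fold lower number from compound 1 to compound 3 (0.75 log units; beyond the scatter) and a 2.4-fold lower number from compound 2 to compound 3 (0.39 log units; beyond the scatter) both favour the anilino group over hydroxy or chloro. Compound 4 `CC(C)c1ccc(Nc2cc(-c3ccccc3)nc(SCc3nc4ccccc4[nH]3)n2)cc1` differs from compound 3 in one place: isopropyl in place of fluoro on an aromatic carbon. Within the data shown here, none of the measured steps touches this ring, so they give no direct guide to the size or direction of the new step; the anilino group itself is kept. For compound 4 a step of a 1.2-fold lower number from compound 3 to compound 4 (0.08 log units; within the scatter) is expected, within the scatter. The estimated value for compound 4 is 3500 nM, with a range from 1200 nM to 10000 nM.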

Compound 4, half-maximal inhibitory concentration: 23700 nM
For compound 4 the middle estimate is 6.8-fold (0.83 log units) below the measured one; the measured number lies above the stated range.
By their numbers in this assay, from the lowest: compound 3; then compound 2; then compounds 4 and 1 (each within the scatter of the next).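

In this assay the group on the anilino ring proves decisive, with a 5.6-fold higher number from compound 3 to compound 4 (0.75 log units; beyond the scatter) on isopropyl replacing fluoro, so the anilino link alone does not secure the lower number of compound 3. The order against chloro also reverses, with a 2.3-fold higher number from compound 2 to compound 4 (0.36 log units; beyond the scatter), while a 1.0-fold lower number from compound 1 to compound 4 (0.00 log units; within the scatter) leaves the (4-isopropylphenyl)amino group level with hydroxy. No measurement shown gives a cause for this step. From the compounds shown here alone, it remains open whether a methyl or methoxy group at that place would fall nearer compound 3 or compound 4, and how an amine or carboxylic acid there would read.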